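Furan to Ethoxyphenyl: What Cytotoxicity Limits Can Tell

The compounds below may be only part of what the source reports. "The series", "measured", "known", "first", "only" and "open" are said of these compounds alone.

Two measured compounds share one core and differ only in the ring hanging from it. Compound 1 is `CCOC(=O)CCCCCOc1cccc(CN(C(=O)c2ccc(-c3cccc(OC(C)C)c3)cc2)C(C)C)c1` and compound 2 is `CCOC(=O)CCCCCOc1cccc(CN(C(=O)c2ccc(-c3ccco3)cc2)C(C)C)c1`. In an ADME assay on HepG2 cells (Homo sapiens) for cytotoxicity, read by CellTiter-Glo and resazurin assay, with a stated time of 72 h (a higher number here means that more compound is needed for the effect, a lower number that less compound is needed), compound 1 gives only a limit, > 26000 nM. In this assay compound 2 likewise gives only a limit, > 26000 nM. The step between them, a step that the two limits leave unreadable from compound 1 to compound 2, cannot be sized because both ends sit at the limit of > 26000 nM in this assay, at which 2 of the 2 values shown sit. Compound 2 thus stands at the edge of what this assay can report, with no number fixing its place more closely.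

Compound 3 is `CCOC(=O)CCCCCOc1cccc(CN(C(=O)c2ccc(-c3cccc(OCC)c3)cc2)C(C)C)c1`. It differs from compound 2 by 3-ethoxyphenyl in place of furan-2-yl on an aromatic carbon. Going by the values given here, the only measured step, the one from compound 1 to compound 2, bears on this change, and with both ends at a limit it shows no size in either direction. Compound 3 resembles compound 1 in carrying a six-membered carbon ring with an alkoxy group, and compound 1 reached the limit > 26000 nM. The step expected here is a step that the limit leaves unreadable from compound 2 to compound 3, none beyond the scatter. Compound 3 is estimated to give 40000 nM in this assay, within a range from 15000 nM to 150000 nM, most likely again as a limit.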

Compound 3, half-maximal effective concentration: > 22300 nM
Compound 3 was reported as a limit; the forecaster's own chance of this, stated with the estimate: 85%; the middle value is on the limit's open side.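

In this assay compound 3 gives only a limit, > 22300 nM. Its steps to compound 1 and compound 2, which also give only limits, cannot be read. The compounds shown leave open at what concentration, if any, each of the three would reach the half-maximal effect on these cells, and whether changing the ring alters that concentration at all.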